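The compounds below may be only part of what the source reports. "The series", "measured", "known", "first", "only" and "open" are said of these compounds alone.

Working notes on the series.

Compound 2 `Cc1cc(C)c(CN2CCc3c(Cl)cc(-c4c(C)noc4C)c(Cl)c3C2=O)c(=O)[nH]1` is the reference point here. Within the data shown here, in an assay on cells for inhibition of histone-lysine N-methyltransferase EZH2 (Homo sapiens), read by ELISA, with a stated time of 72 h (on this read-out lower numbers stand for stronger inhibition and higher numbers for weaker inhibition), compound 2 gives 17 nM, the only number it has in this assay; a further entry for compound 2 carries no single number. Compound 1 `Cc1cc(C)c(CN2CCc3c(Cl)cc(C(CO)c4ccon4)c(Cl)c3C2=O)c(=O)[nH]1`, which shares the core, gives in this assay 7960 nM; 273 nM (2 entries); the spread between its entries, shown in the several entries of compound 1 in this assay, 7960 nM; 273 nM (2 entries), is wide, so compound 1 offers only a rough anchor, and no step between compound 1 and compound 2 is given.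

Compound 3 `Cc1cc(C)c(CN2CCc3c(Cl)cc([C@@H](CO)[C@H]4CCCO4)c(Cl)c3C2=O)c(=O)[nH]1` is the next case. From compound 2 to compound 3 the change is a group of 8 heavy atoms (6 carbon, 2 oxygen; one five-membered non-aromatic ring with 1 hetero atom) in place of a group of 7 heavy atoms (5 carbon, 1 nitrogen, 1 oxygen; one five-membered aromatic ring with 2 hetero atoms), on an aromatic carbon. Among the measured compounds shown here, no measured step of this kind exists, so the expectation rests on the one value of compound 2 and on the loose picture from compound 1. The step from compound 2 to compound 3 is expected to run toward weaker inhibition, estimated at a 6.5-fold higher number from compound 2 to compound 3 (0.81 log units; beyond the scatter), beyond the usual scatter but not by a large margin. For compound 3 in this assay the estimate is 110 nM, with a range from 25 nM to 600 nM.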

Compound 3, half-maximal inhibitory concentration in the histone-lysine N-methyltransferase EZH2 assay: 1020 nM
Estimate against measurement, compound 3: 9.3-fold (0.97 log units) below, and the stated range ends below it.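

This aromatic carbon, ortho to a chloro group and meta to a second one, does not accept every group of similar size: in the histone-lysine N-methyltransferase EZH2 assay, replacing 3,5-dimethyl-1,2-oxazol-4-yl with the group carrying one five-membered non-aromatic ring, 1 hydrogen-bond donor and 2 defined stereocentres gives a 60-fold higher number from compound 2 to compound 3 (1.78 log units; beyond the scatter). Compound 1 could only hint at this, but compound 3, with a single entry of 1020 nM, gives a firm value that falls inside the wide spread of compound 1, 7960 nM; 273 nM (2 entries). In a physicochemical assay for lipophilicity, at pH 7.4 (a lower number here means a more polar compound, a higher number a more lipophilic compound), compound 2 gives 3.1 and compound 3 gives 2.5. The large loss in inhibition comes with a measured shift toward the polar side, a link seen in this one pair only: the measured distribution coefficient of compound 2, 3.1, and of compound 3, 2.5, a number 0.60 log units lower (beyond the scatter)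

The compounds shown leave open which part of the entering group goes with the loss, whether the non-aromatic ring, the hydrogen-bond donor or the stereochemistry, and they do not separate any of these from the shift in lipophilicity. Going by these compounds, it also remains open how this carbon would respond to an amine, a carboxylic acid or a simple phenyl ring in place of 3,5-dimethyl-1,2-oxazol-4-yl.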